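A few compounds are considered here, and "the series" means these few. Any claim that something is new, unique, unknown or untested is made for them only; others in the source may bear on it.

Measured compounds:
Compound 1, `N=C(N)NS(=O)(=O)c1ccc(N/C(S)=N\c2ccnc3cc(C(F)(F)F)ccc23)cc1` — in a functional assay on MDA-MB-231 cells (Homo sapiens) for antiproliferative activity, read by sulforhodamine B assay, with a stated time of 48 h (on this read-out lower numbers stand for stronger inhibition and higher numbers for weaker inhibition), compound 1 is reported as "not active" (no number reported).
Compound 2, `Cc1cc(NS(=O)(=O)c2ccc(N/C(S)=N\c3ccnc4cc(C(F)(F)F)ccc34)cc2)on1` — in this assay compound 2 gives 80300 nM.

Among the measured compounds shown here, compound 2 holds the only numerical result in this assay; compound 1 has no number attached to it, so the two cannot be compared as a step, and no step between measured compounds is available at all. What compound 2 does show is a very weak effect, and that is the sole anchor for anything said about compound 3.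

Compound 3, `Cc1noc(NS(=O)(=O)c2ccc(N/C(S)=N\c3ccnc4cc(C(F)(F)F)ccc34)cc2)c1C`, differs from compound 2 in one place: methyl in place of hydrogen on an aromatic carbon. The change is a methyl in place of hydrogen on an aromatic carbon of the five-membered ring that carries the sulfonamide nitrogen.

For the measured compounds named here, with only one number in hand, there is no basis for expecting a directional shift. The estimated step of a 1.1-fold lower number from compound 2 to compound 3 (0.06 log units; within the scatter) from compound 2 to compound 3 is expected to stay within the usual scatter of this assay. Compound 3 is therefore estimated at 70000 nM in this assay, with a range from 25000 nM to 200000 nM.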

Compound 3, half-maximal inhibitory concentration: 27900 nM
Estimate against measurement, compound 3: 2.5-fold (0.40 log units) above; the range from low to high includes it.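

Adding a methyl to the aromatic carbon of the five-membered ring, which turns the 3-methyl-1,2-oxazol-5-yl group into the 3,4-dimethyl-1,2-oxazol-5-yl group, gives a 2.9-fold lower number from compound 2 to compound 3 (0.46 log units; beyond the scatter) in this assay. Among the compounds shown here, this is the first readable step, and it shows that this ring carbon is not silent: one added carbon is enough to move the read-out towards stronger inhibition, even though the number for compound 3 remains high in absolute terms. Nothing available on the compounds accounts for the shift, so it stands as an observation without an explanation.

As far as these compounds go, whether the trend carries on with a longer chain such as ethyl at this ring carbon, or how an amine or a chlorine atom would behave in the same place, remains open. For the compounds shown here, also open is how other groups on the sulfonamide nitrogen compare, since compound 1 is reported only as "not active" (no number reported) and so offers no step to set beside this one.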